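Hydroquinone-to-dione exchange on the pyrazole series

The source may report more compounds than this note shows. Statements on the series, on what has been measured and on what is new or still open speak of the compounds shown alone.

Measured so far:
compound 1 `Oc1ccc(O)c(-c2cc(-c3ccccc3)nn2-c2ccccc2)c1` — 35700 nM
compound 2 `Oc1ccc(O)c(-c2cc(-c3ccc(Cl)cc3)nn2-c2ccccc2)c1` — 3430 nM
compound 3 `CC(=O)NS(=O)(=O)c1ccc(-n2nc(-c3ccc(Cl)cc3)cc2-c2cc(O)ccc2O)cc1` — 37400 nM

In a functional assay on cells (Leukemia cell, Homo sapiens) for cytotoxicity, read by sulforhodamine B assay, with a stated time of 48 h (on this read-out higher numbers stand for weaker inhibition of growth and lower numbers for stronger inhibition of growth), compound 2 gives the lowest number of the three. The step of a 10-fold lower number from compound 1 to compound 2 (1.02 log units; beyond the scatter) separates it from compound 1, and the step of an 11-fold higher number from compound 2 to compound 3 (1.04 log units; beyond the scatter) separates it from compound 3; both steps are beyond the scatter, so compound 2 stands as the strongest inhibitor of growth among the measured compounds.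

Compound 4 `O=C1C=CC(=O)C(c2cc(-c3ccc(Cl)cc3)nn2-c2ccccc2)=C1` has not been measured. It differs from compound 2 by a group of 8 heavy atoms (6 carbon, 2 oxygen; one six-membered non-aromatic ring of carbon only) in place of a group of 8 heavy atoms (6 carbon, 2 oxygen; one six-membered aromatic ring of carbon only), on an aromatic carbon: a non-aromatic six-membered ring with two oxygens and four double bonds outside aromatic rings in place of the 2,5-dihydroxyphenyl group, on the aromatic carbon of the shared core next to the ring nitrogen.

Neither measured step bears directly on this change: the step from compound 1 to compound 2 alters the 4-chlorophenyl side, and the step from compound 2 to compound 3 alters the phenyl on the ring nitrogen. Among the measured compounds shown here, no measured pair exchanges the 2,5-dihydroxyphenyl group itself. The expectation therefore rests on compound 2 alone, with a step of a 1.4-fold lower number from compound 2 to compound 4 (0.14 log units; within the scatter) that is estimated to stay close to the scatter in either direction. Compound 4 is estimated at 2500 nM, within the range 400 nM to 15000 nM.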

Compound 4, concentration for 50% growth inhibition: 27800 nM
The estimate for compound 4 lay 11-fold (1.05 log units) below the measured number, and the stated range ends below it.
By their numbers in this assay, from the lowest: compound 2; then compounds 4, 1 and 3 (each within the scatter of the next).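

In this assay, the first exchange made at the 2,5-dihydroxyphenyl position itself, on the aromatic carbon next to the ring nitrogen, gives an 8.1-fold higher number from compound 2 to compound 4 (0.91 log units; beyond the scatter) and counts as a modest change. Among the compounds shown here, the earlier steps touched only the 4-chlorophenyl side and the phenyl on the ring nitrogen, so this is the first sign that the number also responds to the group at this position, even though the heavy-atom count and composition stay the same and the group goes from a six-membered aromatic ring with 2 hydrogen-bond donors to a non-aromatic one with 4 double bonds outside aromatic rings and 0 donors. Nothing available indicates which of these counted differences carries the step.

Open, from the compounds shown here alone, is whether a 2,5-dimethoxyphenyl group or a 2,5-diaminophenyl group at this position stays with compound 2 or moves toward compound 4, which would begin to separate the hydroxyl hydrogens from the ring itself. Also open, going by these compounds, is whether the same exchange gives a step of similar size on the core of compound 1, without the chloro group, or on compound 3, with the acetylsulfamoyl group.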